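This account rests on a few compounds, and the source may have more. Where it says the series, first, only, none or still open, it means among the compounds named here.

For the measured compounds named here, the three compounds measured so far share one core and differ only in the group attached to its far end. Compound 2 `Cc1ccc(-c2ccc(NCc3ccccc3O)cc2)cc1` carries a methyl there, and in a functional assay on Jurkat cells (Homo sapiens) for activation, with a stated time of 24 h (on this read-out higher numbers stand for an effect only at larger amounts of compound and lower numbers for an effect already at smaller amounts), compound 2 gives 3790 nM. Among the two numbers recorded this is the higher one, but its nearest neighbour lies close: compound 3 `Oc1ccccc1CNc1ccc(-c2cccc(F)c2)cc1` gives 2020 nM in this assay, and a 1.9-fold lower number from compound 2 to compound 3 (0.27 log units; within the scatter). Compound 1 `CN1CCN(c2ccc(NCc3ccccc3O)cc2)CC1`, whose end group is of a different kind, is reported in this assay as "not active" (no number reported), with no number given, so it offers no scale for comparison.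

Compound 4 `CC(C)Oc1ccc(-c2ccc(NCc3ccccc3O)cc2)cc1` differs from compound 2 in one place: isopropoxy in place of methyl on an aromatic carbon. Going by the values given here, the only measured step that changes a substituent on this same ring is the one from compound 2 to compound 3, a 1.9-fold lower number from compound 2 to compound 3 (0.27 log units; within the scatter), and it stayed within the scatter. Among the compounds with values here, no measured compound carries an isopropoxy group or any oxygen on this ring, so there is nothing to suggest a move in either direction. The step from compound 2 to compound 4 is therefore expected to be small, about a 1.3-fold lower number from compound 2 to compound 4 (0.10 log units; within the scatter). Compound 4 is accordingly estimated to give around 3000 nM in this assay, with a plausible range from 900 nM to 10000 nM.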

Compound 4, half-maximal effective concentration: 5940 nM
Estimate against measurement, compound 4: 2.0-fold (0.30 log units) below; low and high end bracket the measured number.
By their numbers in this assay, from the lowest: compounds 3, 2 and 4 (each within the scatter of the next, the first and the last beyond it).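

With isopropoxy in place of methyl at the ring position para to a large group, the step is a 1.6-fold higher number from compound 2 to compound 4 (0.20 log units; within the scatter) in this assay, so this exchange, which brings in more heavy atoms, an oxygen and a hydrogen-bond acceptor, does not move the number beyond the usual scatter. The earlier step, with 3-fluorophenyl in place of 4-methylphenyl, had shown this only for a fluorine-bearing end ring, whereas compound 4 extends the same result to an ether oxygen and a branched group on this ring. No measurement presented here gives a reason for this outcome.

Because the oxygen and the extra carbons enter together in this one change, the compounds shown cannot separate their contributions, and methoxy at this position would be the natural group for telling them apart. They also leave open whether an amine, a carboxylic acid or a longer alkoxy chain at this position would shift the number beyond the scatter, or whether this position stays as flat for such groups as it has so far.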